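A few compounds are considered here, and "the series" means these few. Any claim that something is new, unique, unknown or untested is made for them only; others in the source may bear on it.

Measured so far in a functional assay on Shh Light II cells (Mus musculus) for inhibition, read by a luciferase reporter (on this read-out higher numbers stand for weaker inhibition and lower numbers for stronger inhibition), are two compounds:
compound 1 `O=C(Nc1ccccc1Cl)N1CCN(c2nc(-c3ccc4ccccc4n3)no2)CC1` gives 140 nM
compound 2 `O=C(CC1CCCCCC1)N1CCC(c2nc(-c3ccc4ccccc4n3)no2)CC1` gives 840 nM

Compound 2 has the higher of the two numbers, and compound 2 at 840 nM and compound 1 at 140 nM are separated by a gap that lies beyond the usual scatter. Compound 3 `O=C(NCC1CCC1)N1CCC(c2nc(-c3ccc4ccccc4n3)no2)CC1` differs from compound 2 by one change (cyclobutylmethyl)amino in place of cycloheptylmethyl on a carbonyl carbon that puts (cyclobutylmethyl)amino in place of cycloheptylmethyl on a carbonyl carbon. Among the measured compounds shown here, no measured pair isolates this change. For the measured compounds named here, the only guide is compound 1 with 140 nM on the lower side, which also has a substituted amino group on a carbonyl carbon, although it differs from compound 2 elsewhere too. A modest move toward stronger inhibition is therefore expected, an estimated 2.1-fold lower number from compound 2 to compound 3 (0.32 log units; beyond the scatter) near the edge of the scatter. For compound 3 the estimated value is 400 nM with an expected range from 100 nM to 1500 nM in this uncertain case.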

Compound 3, half-maximal inhibitory concentration: 410 nM
Compound 3: middle estimate off by 1.0-fold (0.01 log units), on the low side; the measured number falls inside the stated range.
By their numbers in this assay, from the lowest: compound 1; then compound 3; then compound 2.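

In this assay, among the compounds shown here, the group on the carbonyl carbon turns out to affect the read-out: with the rest of the molecule unchanged, putting (cyclobutylmethyl)amino in place of cycloheptylmethyl gives a 2.0-fold lower number from compound 2 to compound 3 (0.31 log units; beyond the scatter) as the only step read at this position. Compound 1 differs from compound 2 in more than one place, so it could not isolate this change. The change swaps a seven-membered ring for a four-membered one and also brings in a nitrogen with one hydrogen-bond donor, and no measurement here explains the step.

Going by these compounds, it remains open which of these differences carries the step, and (cycloheptylmethyl)amino or cyclobutylethyl on the same carbonyl carbon would separate them. On these data alone, how an open chain such as butylamino would compare at this place also remains open.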